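A few compounds are considered here, and "the series" means these few. Any claim that something is new, unique, unknown or untested is made for them only; others in the source may bear on it.

In a functional assay, with a stated time of 10 min (a lower number here means a stronger inhibitor, a higher number a weaker inhibitor), compound 1 (`O=c1cc(/C=C/c2ccc(Cl)cc2)[nH]cc1O`) gives 11500 nM and compound 2 (`Cn1cc(O)c(=O)cc1/C=C/c1ccccc1`) gives 2110 nM, the lower of the two numbers and apart from the other beyond the usual scatter. Compound 3 (`Cn1cc(O)c(=O)cc1/C=C/c1ccc(Cl)cc1`) differs from compound 2 by chloro in place of hydrogen on an aromatic carbon, para to a large group: chloro in place of hydrogen on an aromatic carbon. For the measured compounds named here, no measured pair shows this change alone, so only a small shift toward a lower number in this assay is expected, possibly none beyond the scatter. The expected step is a 1.4-fold lower number from compound 2 to compound 3 (0.15 log units; within the scatter). Compound 3 is estimated at 1500 nM, within a range of 500 nM to 5000 nM.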

Compound 3, half-maximal inhibitory concentration: 5720 nM
Beside the measured number, compound 3's estimate is 3.8-fold (0.58 log units) below it, and the stated range ends below it.
By their numbers in this assay, from the lowest: compound 2; then compounds 3 and 1 (each within the scatter of the next).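

Chloro in place of hydrogen on this aromatic carbon, para to a large group, does not help in this assay: it gives a 2.7-fold higher number from compound 2 to compound 3 (0.43 log units; beyond the scatter). With chloro held constant, methyl in place of hydrogen on the aromatic nitrogen gives a 2.0-fold lower number from compound 1 to compound 3 (0.30 log units; within the scatter), so this change has no effect that can be separated from the scatter. Nothing available accounts for either step. On these data alone, whether fluoro, methoxy or an amine at this carbon behaves like chloro remains open. Also open, as far as these compounds go, is whether a longer chain on the nitrogen moves the number beyond the scatter.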